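Chloropropenyloxy extension of the methoxy-imine series

The compounds below may be only part of what the source reports. "The series", "measured", "known", "first", "only" and "open" are said of these compounds alone.

Two members of the series have a number for a physicochemical assay for lipophilicity, measured as octanol-water partition; a lower number here means a more polar compound, a higher number a more lipophilic compound. Compound 1 `CCO/N=C/Nc1cc(Cl)c([S+]([O-])CC)c(Cl)c1` gives 2.9 in this assay, and compound 2 `C#CCc1c(Cl)cc(N/C=N/OC)cc1Cl` gives 3.3, the higher of the two, the gap between them lying beyond the scatter. Compound 3 `C#CCc1c(Cl)cc(N/C=N/OC/C=C\Cl)cc1Cl` is not yet measured in this assay. It differs from compound 2 by 2-chloroethenyl in place of hydrogen on a saturated chain carbon bound to an oxygen. Going by the values given here, no measured step of this kind exists, so the expectation rests on the change alone: a step upward, clearly beyond the scatter, estimated as a number 1.10 log units higher from compound 2 to compound 3 (beyond the scatter). For compound 3 the expected value in this assay is 4.4, within 3.9 to 4.9.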

Compound 3, partition coefficient: 3.9
The estimate for compound 3 lay 0.50 log units above the measured number, within the range that was stated.
By their numbers in this assay, from the lowest: compound 1; then compound 2; then compound 3.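

In this assay the change of methoxy to (3-chloroprop-2-en-1-yl)oxy reads a number 0.60 log units higher from compound 2 to compound 3 (beyond the scatter) and gives the series its first measured step at this place. The read-out at this saturated chain carbon bound to an oxygen therefore responds to 2-chloroethenyl in place of hydrogen by more than the scatter. Nothing at hand explains the size or direction of this step.

A single step cannot separate the chlorine from the added carbon chain. A plain propyl chain, or an amine on the same chain, would show how far the step depends on 2-chloroethenyl itself.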